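Benzyl for tert-butyl on the amide nitrogen

This account rests on a few compounds, and the source may have more. Where it says the series, first, only, none or still open, it means among the compounds named here.

In a functional assay on PC-3 cells (Homo sapiens) for inhibition, read by sulforhodamine B assay, with a stated time of 72 h (on this read-out lower numbers stand for stronger inhibition and higher numbers for weaker inhibition), compound 1 `Nc1sc(-c2ccc(Cl)cc2)c(-c2ccc(Cl)cc2)c1C(=O)NC1CCC(O)CC1` gives 5670 nM, the lowest of three numbers. Compound 2 `CCCCNC(=O)c1c(N)sc(-c2ccc(Cl)cc2)c1-c1ccc(Cl)cc1` gives 17800 nM and compound 3 `CC(C)(C)NC(=O)c1c(N)sc(-c2ccc(Cl)cc2)c1-c1ccc(Cl)cc1` gives 15100 nM. Compound 3 thus holds the middle place, although the step of a 1.2-fold lower number from compound 2 to compound 3 (0.07 log units; within the scatter) lies within the scatter, while the step of a 2.7-fold higher number from compound 1 to compound 3 (0.43 log units; beyond the scatter) lies beyond it. Compound 4 `Nc1sc(-c2ccc(Cl)cc2)c(-c2ccc(Cl)cc2)c1C(=O)NCc1ccccc1` carries benzyl in place of tert-butyl on an amide-type nitrogen. For the measured compounds named here, the steps of a 1.2-fold lower number from compound 2 to compound 3 (0.07 log units; within the scatter) and a 3.1-fold higher number from compound 1 to compound 2 (0.50 log units; beyond the scatter) are the closest guides, but no measured compound has a ring of this kind there. Only a small change is therefore expected, with a 1.4-fold lower number from compound 3 to compound 4 (0.14 log units; within the scatter) as the estimated step, within the scatter. For compound 4 the estimate in this assay is 11000 nM, with an expected range of 4500 nM to 25000 nM.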

Compound 4, half-maximal inhibitory concentration: 31800 nM
Compound 4: middle estimate off by 2.9-fold (0.46 log units), on the low side; the whole stated range lies below it.
By their numbers in this assay, from the lowest: compound 1; then compounds 3, 2 and 4 (each within the scatter of the next, the first and the last beyond it).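

In this assay an aromatic ring on the amide nitrogen brings no gain: benzyl for tert-butyl gives a 2.1-fold higher number from compound 3 to compound 4 (0.32 log units; beyond the scatter), while the comparison with the butyl chain gives a 1.8-fold higher number from compound 2 to compound 4 (0.25 log units; within the scatter), which does not separate these two compounds. The step of a 5.6-fold higher number from compound 1 to compound 4 (0.75 log units; beyond the scatter) leaves 4-hydroxycyclohexyl with the lowest number of the four. Nothing measured here accounts for these steps. The compounds shown leave open whether plain cyclohexyl would match the 4-hydroxycyclohexyl of compound 1, and whether an amine on the ring of the benzyl would shift the number.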